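The source may report more compounds than this note shows. Statements on the series, on what has been measured and on what is new or still open speak of the compounds shown alone.

Compound 1 `C=CC(C)(C/C=C(\C)CCC=C(C)C)c1ccc(OCc2ccccc2)c(O)c1` and compound 2 `C=CC(C)(C/C=C(\C)CCC=C(C)C)c1ccc(O)c(OCc2ccccc2)c1` are made of the same atoms joined differently; how their two cores differ is not broken down here. In a functional assay on SF-295 cells (Homo sapiens) for cytotoxicity, read by MTT assay, with a stated time of 72 h (on this read-out lower numbers stand for stronger inhibition and higher numbers for weaker inhibition), compound 1 is reported as "not active" (no number reported), with no number attached. In this assay compound 2 gives 18.2 ug/mL. Compound 3 `C=CC(C)(C/C=C(\C)CCC=C(C)C)c1ccc(O)c(OC)c1` comes from compound 2 through a single change, (hydrogen in place of phenyl on a saturated chain carbon bound to an oxygen on an aromatic ring). In this assay compound 3 gives 20.7 ug/mL, so the change produced a 1.1-fold higher number from compound 2 to compound 3 (0.06 log units; within the scatter), a step too small to separate the two compounds.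

Compound 4 `C=CC(C)(C/C=C(\C)CCC=C(C)C)c1ccc(OC)c(O)c1` stands to compound 1 as compound 3 stands to compound 2: hydrogen in place of phenyl on a saturated chain carbon bound to an oxygen on an aromatic ring. The place of the change is described in the same words for both pairs, so this counts as the same change, made on a different core. Compound 1 gave no number in this assay, so the step from compound 1 to compound 4 cannot be measured as a ratio. The expectation is that this step is small, like the earlier one, since the same change gave a 1.1-fold higher number from compound 2 to compound 3 (0.06 log units; within the scatter). Compound 4 is therefore expected to remain weak, because compound 1 shows "not active" (no number reported) in this assay. In this assay compound 4 is estimated at about 45 ug/mL, within a range from 15 ug/mL to 120 ug/mL, with a real chance that no number at all is reported for it.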

Compound 4, half-maximal inhibitory concentration: > 25 ug/mL
Compound 4 was reported as a limit; the forecaster's own chance of this, stated with the estimate: 55%; the middle value lies beyond the limit too.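

In this assay compound 4 is recorded as > 25 ug/mL, which is a limit and not a number. Going by these compounds alone, compound 1 is recorded as "not active" (no number reported), so no step between compound 1 and compound 4 can be read. The compounds shown leave open how far the change from benzyloxy to methoxy moves the read-out on the core of compound 1, if it moves it at all.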